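Sulfonyl aryl exchange on a shared core: expected cytotoxicity

The source may report more compounds than this note shows. Statements on the series, on what has been measured and on what is new or still open speak of the compounds shown alone.

Compound 3 `O=S(=O)(Nc1ccc2oc(-c3ccccc3)nc2c1)c1cccc(O)c1` was tested in an ADME assay on HEK293 cells (Homo sapiens) for cytotoxicity, read by resazurin assay, with a stated time of 48 h (on this read-out higher numbers stand for lower toxicity in this test and lower numbers for higher toxicity in this test), and gave only a limit of the assay, > 100000 nM. Compound 1 `O=S(=O)(Nc1ccc2oc(-c3ccccc3)nc2c1)c1cccc(C(F)(F)F)c1` likewise gave only a limit in this assay, > 100000 nM. Compound 2 `O=S(=O)(Nc1ccc2oc(-c3ccccc3)nc2c1)c1ccccc1Cl` gave a number in this assay, 73000 nM. Two of the three values therefore sit at the limit of > 100000 nM in this assay, at which 2 of the 3 values shown sit, and compound 3 cannot be placed more closely than at that limit. The step that the two limits leave unreadable from compound 1 to compound 3. The step of an at least 1.3-fold higher number from compound 2 to compound 3 (0.13 log units; that floor lies within the scatter).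

Compound 4 `COc1ccc(Cl)cc1S(=O)(=O)Nc1ccc2oc(-c3ccccc3)nc2c1` has not yet been measured. It differs from compound 3 in one place: 5-chloro-2-methoxyphenyl in place of 3-hydroxyphenyl on a sulfonyl sulfur. Among the compounds with values here, of the measured steps only that from compound 2 to compound 3 resembles this change, exchanging a chlorine-bearing phenyl group for 3-hydroxyphenyl on the sulfonyl sulfur, and its floor lies within the scatter. In this assay the step toward compound 4 is therefore expected to be small, if anything toward a lower number, and possibly not beyond the scatter. The expected step is an at least 1.2-fold lower number from compound 3 to compound 4 (0.09 log units; that floor lies within the scatter). Compound 4 is expected to give 80000 nM in this assay, with a range from 30000 nM to 150000 nM.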

Compound 4, half-maximal cytotoxic concentration: 74000 nM
Compound 4: the middle estimate sits 1.1-fold (0.03 log units) above what was measured, within the range that was stated.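

Compound 4 shows that 5-chloro-2-methoxyphenyl, on a sulfonyl sulfur whose other neighbour is the sulfonamide nitrogen, gives a readable number in this assay, and among the four compounds shown both numbers now belong to chlorine-bearing phenyl groups, while 3-hydroxyphenyl in compound 3 and the trifluoromethyl-bearing group in compound 1 give limits of the assay. The two chlorine-bearing groups cannot be told apart here, since the step of a 1.0-fold higher number from compound 2 to compound 4 (0.01 log units; within the scatter) lies within the scatter, so this exchange on the shared core adds nothing readable to what compound 2 already showed. The step of an at least 1.3-fold lower number from compound 3 to compound 4 (0.13 log units; that floor lies within the scatter) also has a floor within the scatter, and it can be read only as a floor because one end of it is a limit of the assay: the limit of > 100000 nM in this assay, at which 2 of the 4 values shown sit.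

The compounds shown do not separate the chlorine from the methoxy within 5-chloro-2-methoxyphenyl, and they leave open what a phenyl group bearing only a methoxy, an amine or a carboxylic acid would give at this position. On these data alone, the step between the two limits cannot be read, so how compound 1 and compound 3 stand to each other also remains open.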